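Toward compound 4: a dichlorophenyl variant of an inactive series

This account rests on a few compounds, and the source may have more. Where it says the series, first, only, none or still open, it means among the compounds named here.

Compound 1 `N#CC1=C(N)Oc2c(c3nc4ccccc4nc3c3ccccc23)C12C(=O)N(Cc1cnnn1-c1ccc(Cl)cc1)c1ccccc12`: in an ADME assay on L02 cells (Homo sapiens) for antiproliferative activity, read by MTT assay, with a stated time of 48 h (on this read-out higher numbers stand for weaker inhibition and lower numbers for stronger inhibition), compound 1 gives > 50000 nM, which is a limit of the assay rather than a number.
Compound 2 `N#CC1=C(N)Oc2c(c3nc4ccccc4nc3c3ccccc23)C12C(=O)N(Cc1cnnn1-c1ccccc1Br)c1ccccc12`: in this assay compound 2 gives > 50000 nM, again a limit.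
Compound 3 `Cc1ccc(Cl)cc1-n1nncc1CN1C(=O)C2(C(C#N)=C(N)Oc3c2c2nc4ccccc4nc2c2ccccc32)c2ccccc21`: in this assay compound 3 gives > 50000 nM, also a limit.

All three measured compounds share one core and differ only in the aryl group on the aromatic nitrogen of the triazole ring. Compound 3 stands where the other two stand, at the limit of > 50000 nM in this assay, at which 3 of the 3 values shown sit; no number separates it from them. The steps that touch the same position, a step that the two limits leave unreadable from compound 1 to compound 2, a step that the two limits leave unreadable from compound 1 to compound 3 and a step that the two limits leave unreadable from compound 2 to compound 3, all lie between two limits, so their size cannot be read.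

Compound 4 `N#CC1=C(N)Oc2c(c3nc4ccccc4nc3c3ccccc23)C12C(=O)N(Cc1cnnn1-c1ccc(Cl)c(Cl)c1)c1ccccc12` has not yet been measured. Its change from compound 3 is 3,4-dichlorophenyl in place of 5-chloro-2-methylphenyl on an aromatic nitrogen, with the place described as on an aromatic nitrogen of a five-membered aromatic ring with three nitrogens. Among the measured compounds shown here, every measured exchange at this position left the limit untouched, and no step is readable, so no shift in this assay beyond the scatter is expected here either; the step that the limit leaves unreadable from compound 3 to compound 4 is an estimate carried by those unreadable steps. Compound 4 is therefore expected to show weak inhibition, with an estimated value of 80000 nM and a range from 40000 nM to 200000 nM, most likely reported once more as a limit.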

Compound 4, half-maximal inhibitory concentration: > 50000 nM
Compound 4: only a limit was reported (the forecaster's own chance of this, stated with the estimate: 85%); the middle value is on the limit's open side.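

In this assay compound 4 gives > 50000 nM, a limit rather than a number. Its steps to compound 1, compound 2 and compound 3 cannot be read, since all four compounds stand at the same limit: the limit of > 50000 nM in this assay, at which 4 of the 4 values shown sit. The compounds shown leave open how far each lies beyond that limit, and whether changing the aryl group on this aromatic nitrogen alters inhibition at all.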